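This account rests on a few compounds, and the source may have more. Where it says the series, first, only, none or still open, it means among the compounds named here.

For the measured compounds named here, compound 1 `O=C(CCCCC1CCSS1)Nc1ccc(Cl)cn1` is the only compound here with a number. In a functional assay on PC-3 cells (Homo sapiens) for inhibition, read by MTT assay, with a stated time of 24 h, tested at 0.1 ug/mL (on this read-out lower numbers stand for less inhibition of growth and higher numbers for more inhibition of growth at the one concentration tested), compound 1 gives 2.22%, a weak effect at the single concentration tested. Compound 2 `O=C(CCCCC1CCSS1)Nc1ccc(Br)cn1` has no result in this assay, recorded as "not determined" (no result reported). Compound 3 `O=C(CCCCC(S)CCS)Nc1ccc(Cl)cn1` has not yet been tested. It differs from compound 1 in one place: a group of 5 heavy atoms (3 carbon, 2 sulfur; no ring) in place of a group of 5 heavy atoms (3 carbon, 2 sulfur; one five-membered non-aromatic ring with 2 hetero atoms), on a saturated chain carbon, four bonds along the chain from a carbonyl carbon. Going by the values given here, no step between measured compounds is available to guide the expectation, so the change has to be judged on its own. The expected step of a number 1.8 percentage points higher from compound 1 to compound 3 (within the scatter) is small and lies within the usual scatter. Compound 3 is estimated at 4%, within -8% to 18%.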

Compound 3, percent growth inhibition at one concentration: "not active" (no number reported)
No number was reported for compound 3; no gap can be computed for the estimate.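

For the compounds shown here, compound 3 is recorded only as "not active" (no number reported) in this assay so no step from compound 1 to compound 3 can be read. No other measurement bears on this result. From the compounds shown here alone, whether swapping the ring for 1,3-disulfanylpropyl changes growth inhibition remains open.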